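This account rests on a few compounds, and the source may have more. Where it says the series, first, only, none or still open, it means among the compounds named here.

Compound 2 `CN(C)C(=O)c1cc2cnc(Nc3ccc(S(=O)(=O)NCCCCN=C=S)cc3)nc2n1C1CCCC1` gives 29.9% in a functional assay on NCI-H1299 cells (Homo sapiens) for inhibition, read by CCK-8 assay, with a stated time of 72 h, tested at 1 uM (a higher number here means a stronger effect of the compound at the concentration tested, a lower number a weaker effect), the lowest of the two numbers in hand; its nearest neighbour, compound 1 `CN(C)C(=O)c1cc2cnc(Nc3ccc(S(=O)(=O)NCCCN=C=S)cc3)nc2n1C1CCCC1`, gives 41.3% in this assay. Compound 3 `CN(C)C(=O)c1cc2cnc(Nc3ccc(S(=O)(=O)NCCCCCN=C=S)cc3)nc2n1C1CCCC1` differs from compound 2 by a group of 4 heavy atoms (2 carbon, 1 nitrogen, 1 sulfur; no ring) in place of a group of 3 heavy atoms (1 carbon, 1 nitrogen, 1 sulfur; no ring), on a saturated chain carbon, four bonds along the chain from a sulfonamide nitrogen. Among the compounds with values here, the one measured step that bears on this is the same kind of change three bonds along the chain from the sulfonamide nitrogen, a number 11.4 percentage points lower from compound 1 to compound 2 (beyond the scatter). A further step of that kind, a number 7.9 percentage points lower from compound 2 to compound 3 (within the scatter), is therefore expected, downward and modest. Compound 3 is estimated at 22%, with a range from 8% to 38%.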

Compound 3, a percentage reported as inhibition, at one concentration (the size of the read-out at that concentration, not a potency): 52.1%
Beside the measured number, compound 3's estimate is 30.1 percentage points below it, outside the stated range (above it).
By their numbers in this assay, from the lowest: compound 2; then compound 1; then compound 3.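

In this assay the step four bonds along the chain from the sulfonamide nitrogen runs opposite to the one before it, with a number 22.2 percentage points higher from compound 2 to compound 3 (beyond the scatter) and, across both steps, a number 10.8 percentage points higher from compound 1 to compound 3 (beyond the scatter). Lengthening the chain therefore gives no steady fall across these compounds: compound 2 is lowest and compound 3 highest, and compound 3 goes against any downward trend. Nothing available accounts for this reversal. Going by these compounds, whether a longer chain would raise or lower the number remains open, as does the effect of an amine on that saturated chain carbon.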